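This account rests on a few compounds, and the source may have more. Where it says the series, first, only, none or still open, it means among the compounds named here.

Compound 1 `CO[C@@H](c1ccccc1)[C@H](O)[C@@H]1CC=CC(=O)O1` carries a methyl on one oxygen, while compound 2 `O=C1C=CC[C@@H]([C@@H](O)[C@@H](O)c2ccccc2)O1` carries hydrogen there. In a functional assay on HepG2 cells (Homo sapiens) for cytotoxicity, read by MTT assay, with a stated time of 72 h (on this read-out higher numbers stand for weaker inhibition and lower numbers for stronger inhibition), compound 1 gives only a limit, > 10000 nM. In this assay compound 2 likewise gives only a limit, > 10000 nM. The step that the two limits leave unreadable from compound 1 to compound 2 therefore cannot be sized, which the limit of > 10000 nM in this assay, at which 2 of the 2 values shown sit, shows. Compound 3 `O=C1C=CC[C@@H]([C@H](O)[C@@H](O)c2ccccc2)O1` differs from compound 2 by the two compounds have the same atoms and bonds and differ only in configuration as drawn: 1 of 3 stereo elements differ; a stereocentre at a saturated chain carbon is drawn S in compound 2 and R in compound 3. For the measured compounds named here, no measured step bears on this change, and both values shown are limits, so compound 3 is expected to sit near the same limit, with a step that the limit leaves unreadable from compound 2 to compound 3 expected to stay within the scatter. For compound 3 the estimate is 15000 nM, between 5000 nM and 50000 nM.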

Compound 3, half-maximal inhibitory concentration: > 10000 nM
Compound 3 gave a limit, no number (the forecaster's own chance of this, stated with the estimate: 85%); the middle value is on the limit's open side.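

No step can be read between compound 2 and compound 3, as each gives only a limit in this assay: the limit of > 10000 nM in this assay, at which 3 of the 3 values shown sit.

The compounds shown leave open how the drawn configuration or the methyl on oxygen bears on the read-out.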